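Dropping One Chloro From a Fused Purine-Like Core

The source may hold more compounds than are shown below. What is called first, only, known or untested is meant among the compounds shown, and "the series" means these compounds.

Compound 1 `ClCc1ccc(Cn2cnc3nc(Cl)nc(Cl)c32)cc1` carries two chloro groups on its fused core and a chloromethyl-benzyl arm. In a functional assay on IGROV-1 cells (Homo sapiens) for cytotoxicity, read by sulforhodamine B assay, with a stated time of 48 h (a higher number here means a weaker inhibitor of growth, a lower number a stronger inhibitor of growth), compound 1 gives 1410 nM, the lowest of the three numbers measured. Compound 2 `ClCc1cccc(Cn2cnc3c(Cl)nc(Cl)nc32)c1` gives 2290 nM, within the scatter of compound 1, while compound 3 `Nc1nc(Cl)c2ncn(Cc3cccc(CCl)c3)c2n1` gives 3460 nM, a gap beyond the scatter. Within the data shown here, the only single-place step measured, a 1.5-fold higher number from compound 2 to compound 3 (0.18 log units; within the scatter), swapped a chloro for an amino and stayed within the scatter. Compound 4 `ClCc1ccc(Cn2cnc3ncnc(Cl)c32)cc1` differs from compound 1 by hydrogen in place of chloro on an aromatic carbon, at the position between two ring nitrogen atoms. Among the measured compounds shown here, no measured step matches a chloro removed for hydrogen; with the one chloro swap having moved little, the expected step of a 1.4-fold higher number from compound 1 to compound 4 (0.15 log units; within the scatter) is small. Compound 4 is therefore estimated at 2000 nM, with a range from 700 nM to 6000 nM.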

Compound 4, concentration for 50% growth inhibition: 7580 nM
Beside the measured number, compound 4's estimate is 3.8-fold (0.58 log units) below it, and the stated range ends below it.
By their numbers in this assay, from the lowest: compounds 1, 2 and 3 (each within the scatter of the next, the first and the last beyond it); then compound 4.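

Taking the chloro off this aromatic carbon, between two ring nitrogen atoms, gives (a 5.4-fold higher number from compound 1 to compound 4 (0.73 log units; beyond the scatter)), the first single-place step here to lie beyond the scatter. In this assay, then, growth inhibition by compound 1 depends in part on this chloro, even with the second chloro and the chloromethyl-benzyl arm left unchanged. No measurement shown accounts for the size of this step. Still open, on these data alone, is whether a fluoro, methyl or methoxy group at this position would keep the number of compound 1 or follow compound 4.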